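The source may report more compounds than this note shows. Statements on the series, on what has been measured and on what is new or still open speak of the compounds shown alone.

Of the compounds shown here, two sharing one core have been measured so far in an ADME assay on L6 cells (Rattus norvegicus) for cytotoxicity; a lower number here means a stronger inhibitor, a higher number a weaker inhibitor. The half-maximal inhibitory concentration of compound 1 (`N#Cc1ccccc1N1CCN(C(=O)Cn2cnc([N+](=O)[O-])n2)CC1`) is 213000 nM and that of compound 2 (`O=C(Cn1cnc([N+](=O)[O-])n1)N1CCN(c2ccccn2)CC1`) is 173000 nM on the same read-out. Going by the values given here, these two numbers lie within the scatter of each other, so compound 2 stands level with the only other measured compound.

Compound 3 (`O=C(Cn1cnc([N+](=O)[O-])n1)N1CCN(C(=O)C2CC2)CC1`) keeps the core and changes one group: cyclopropylcarbonyl in place of pyridin-2-yl on an amine nitrogen in a ring. Among the compounds with values here, only one measured step bears on this place, namely a 1.2-fold lower number from compound 1 to compound 2 (0.09 log units; within the scatter) and it replaced 2-cyanophenyl with pyridin-2-yl. Both of those groups contain a six-membered aromatic ring, whereas cyclopropylcarbonyl brings a three-membered non-aromatic ring of carbon only, so this guide is a loose one.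

No shift beyond the scatter is therefore expected in this assay and no firm direction can be given. The expected change is a 1.2-fold higher number from compound 2 to compound 3 (0.08 log units; within the scatter) and it would not stand out from the scatter. For compound 3 the estimate is 210000 nM (expected range 100000 nM to 400000 nM).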

Compound 3, half-maximal inhibitory concentration: 156000 nM
Compound 3: middle estimate off by 1.3-fold (0.13 log units), on the high side; measured number inside the range.
By their numbers in this assay, from the lowest: compounds 3, 2 and 1 (each within the scatter of the next).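

In this assay, cyclopropylcarbonyl on the amine nitrogen in a ring leaves the number within the scatter of both earlier compounds: replacing pyridin-2-yl gives a 1.1-fold lower number from compound 2 to compound 3 (0.04 log units; within the scatter), and replacing 2-cyanophenyl gives a 1.4-fold lower number from compound 1 to compound 3 (0.14 log units; within the scatter). The earlier step compared only groups containing a six-membered aromatic ring, whereas this one brings in a three-membered non-aromatic ring of carbon only and a double bond outside aromatic rings, so among these three compounds a six-membered aromatic ring at this place is not needed for this level of reading. No measurement is available to explain why the number stays level across these groups.

The three groups shown at this place all carry no net charge and leave open whether any group there can move the number beyond the scatter. A basic amine, a carboxylic acid or a longer alkyl chain on this nitrogen would test that, and a change elsewhere on the shared core remains a separate question that these compounds do not touch.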